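From tert-butyl to cyclohexyl on an amide nitrogen

This account rests on a few compounds, and the source may have more. Where it says the series, first, only, none or still open, it means among the compounds named here.

Of the compounds shown here, three have numbers so far in a functional assay on A2780 cells (Homo sapiens) for cytotoxicity, read by MTT assay, with a stated time of 72 h; on this read-out lower numbers stand for stronger inhibition and higher numbers for weaker inhibition. Compound 1 (`CCCCNC(=O)CN(CCCCCC(=O)NO)C(=O)c1ccc(N(C)C)cc1`) gives 1900 nM as its value. Compound 2 (`O=C(CCCCCN(C(=O)c1ccccc1)C1(C(=O)NC2CCCCC2)CCCCC1)NO`) gives 42600 nM as its value. Compound 3 (`CC(C)(C)NC(=O)CN(CCCCCC(=O)NO)C(=O)c1ccccc1`) gives 20700 nM and so stands in the middle: its number is far higher than that of compound 1 and lower than that of compound 2, with the second gap only just beyond the usual scatter.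

Compound 4 (`O=C(CCCCCN(CC(=O)NC1CCCCC1)C(=O)c1ccccc1)NO`) has not yet been measured. It carries cyclohexyl in place of tert-butyl on an amide-type nitrogen. For the measured compounds named here, no measured pair shows this swap alone, so the expectation is loose. Compound 2 also has cyclohexyl on an amide-type nitrogen, but it differs from compound 4 elsewhere too, so it offers only weak guidance. A small move towards a lower number is expected, with nothing beyond the scatter. The expected step is a 1.5-fold lower number from compound 3 to compound 4 (0.17 log units; within the scatter) and would stay within that scatter. In this assay the estimate for compound 4 is 14000 nM with 5000 nM to 38000 nM as the expected range.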

Compound 4, half-maximal inhibitory concentration: 3460 nM
Compound 4: middle estimate off by 4.0-fold (0.61 log units), on the high side, outside the stated range (below it).
By their numbers in this assay, from the lowest: compounds 1 and 4 (each within the scatter of the next); then compound 3; then compound 2.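

For the compounds shown here, this position on the amide-type nitrogen is not indifferent to what sits on it: in this assay the swap of tert-butyl for cyclohexyl gives a 6.0-fold lower number from compound 3 to compound 4 (0.78 log units; beyond the scatter) and is the first single change that can be read in this set. Both groups are carbon only, with no hydrogen-bond donors or acceptors and no net charge, yet they are not interchangeable here. No measurement shown accounts for this step.

The step alone cannot tell whether the ring or the larger number of carbons matters, as the two change together. As far as these compounds go, a cyclopentyl ring or a straight hexyl chain on the same nitrogen would pull these two readings apart, while the effect of cyclohexyl on any other core remains unknown.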